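Hydroxamic acid series: cytotoxicity notes on fluoro removal

The compounds below may be only part of what the source reports. "The series", "measured", "known", "first", "only" and "open" are said of these compounds alone.

Measured so far:
compound 1, `O=C(NO)c1cc2ccn(Cc3ccc(F)cc3F)c2cn1`, limit only: > 320000 nM
compound 2, `O=C(NO)c1cc2ccn(Cc3ccc(F)cc3)c2cn1`: 159000 nM
compound 3, `NC(=O)c1cc(Cn2ccc3cc(C(=O)NO)ncc32)ccc1F`, limit only: > 10000 nM

All three values come from an ADME assay on CEM-SS cells (Homo sapiens) for cytotoxicity, read by XTT assay; a higher number here means that more compound is tolerated, a lower number that less compound is tolerated. Compound 1 is reported only as a limit, (the limit of > 320000 nM in this assay, at which 1 of the 3 values shown sits). Compound 3 is likewise reported only as a limit, (the limit of > 10000 nM in this assay, at which 1 of the 3 values shown sits). Between the two measured neighbours an at least 2.0-fold lower number from compound 1 to compound 2 (0.30 log units; that floor lies within the scatter), the change being (hydrogen in place of fluoro on an aromatic carbon). Then a step that the limit leaves unreadable from compound 2 to compound 3, the change there being carbamoyl in place of hydrogen on an aromatic carbon. The difference between the core of compound 1 and the core of compound 3 is not broken down here.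

Compound 4, `NC(=O)c1cccc(Cn2ccc3cc(C(=O)NO)ncc32)c1`, is not yet measured in this assay and differs from compound 3 by hydrogen in place of fluoro on an aromatic carbon. This is the same kind of change as from compound 1 to compound 2, but the surroundings differ: there the place was ortho to a large group and meta to a fluoro group, here it is ortho to a carbamoyl group and para to a large group. The step expected from compound 3 to compound 4 is a step that the limit leaves unreadable from compound 3 to compound 4. That expectation rests on compound 1 to compound 2, where an at least 2.0-fold lower number from compound 1 to compound 2 (0.30 log units; that floor lies within the scatter) and the floor lies within the scatter, so little movement is foreseen. It also rests on compound 3, whose value > 10000 nM is only a limit. For compound 4 in this assay the estimate is 100000 nM, with a further limit-only report held likely.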

Compound 4, half-maximal cytotoxic concentration: > 10000 nM
Compound 4: a limit, no number; the forecaster's own chance of this, stated with the estimate: 65%; the middle value does not contradict the limit.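

Among the compounds shown here, compound 3 and compound 4 are both reported only as limits in this assay, so no step between them can be read: the limit of > 10000 nM in this assay, at which 2 of the 4 values shown sit.

Still open, going by these compounds, is how far the tolerated concentrations of these two compounds lie from that limit, and whether hydrogen in place of fluoro, ortho to a carbamoyl group, changes the read-out at all.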